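Moving the Pyridine Nitrogen on a Weak Anilinopyrimidine

The compounds below may be only part of what the source reports. "The series", "measured", "known", "first", "only" and "open" are said of these compounds alone.

Compound 1, `CN(C)c1ccc(Nc2nccc(-c3ccccn3)n2)cc1`: 3300 nM
Compound 2, `Cc1cc(-c2ccccn2)nc(Nc2ccc(N(C)C)cc2)n1`: 31900 nM

In a functional assay for inhibition, with Homo sapiens as the target (a lower number here means a stronger inhibitor, a higher number a weaker inhibitor), compound 1 gives 3300 nM. Among the compounds with values here, compound 2 gives 31900 nM in this assay, the highest of the two numbers; its nearest neighbour is compound 1, and the step of a 9.7-fold higher number from compound 1 to compound 2 (0.99 log units; beyond the scatter) is the only measured step in this set.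

Compound 3, `Cc1cc(-c2ccncc2)nc(Nc2ccc(N(C)C)cc2)n1`, differs from compound 2 in one place: pyridin-4-yl in place of pyridin-2-yl on an aromatic carbon. Within the data shown here, no measured step involves a change of this kind; the one step that exists, a 9.7-fold higher number from compound 1 to compound 2 (0.99 log units; beyond the scatter), concerns a methyl group at another position and does not bear on the swap of pyridine isomers. With nothing to guide the direction, the expectation for a 1.4-fold higher number from compound 2 to compound 3 (0.15 log units; within the scatter) is a change that could fall within the scatter or be a modest step either way. Compound 3 is therefore estimated at 45000 nM, with a range from 12000 nM to 180000 nM.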

Compound 3, half-maximal inhibitory concentration: > 24000 nM
Compound 3 ended at the assay's limit; the forecaster's own chance of this, stated with the estimate: 30%; the middle value does not contradict the limit.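

In this assay compound 3 gives > 24000 nM, which is a limit of the assay and not a number. The step from compound 2 to compound 3 therefore cannot be read. The compounds shown leave open whether pyridin-4-yl and pyridin-2-yl differ at all in this setting, and by how much.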